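A few compounds are considered here, and "the series" means these few. Any claim that something is new, unique, unknown or untested is made for them only; others in the source may bear on it.

In an ADME assay (liver) for pharmacokinetics, with Liver microsome (Rattus norvegicus) as the target, read by LC-MS, using microsomes, tested at 2 uM (on this read-out lower numbers stand for slow clearance and higher numbers for fast clearance), compound 1 (`O=C(N[C@@H]1CCCC[C@H]1O)c1cnc(OC2CCC2)c(-c2ccc(Cl)cc2)c1`) gives 0.21 mL/min/kg, compound 2 (`COCCOc1ncc(C(=O)N[C@@H]2CCCC[C@H]2O)cc1-c1ccc(Cl)cc1`) gives 0.098 mL/min/kg and compound 3 (`O=C(N[C@@H]1CCCC[C@H]1O)c1cnc(OCC(F)(F)F)c(-c2ccc(Cl)cc2)c1`) gives 0.023 mL/min/kg, the lowest of the three numbers. Compound 4 (`O=C(N[C@@H]1CCCC[C@H]1O)c1cnc(OCc2ccncc2)c(-c2ccc(Cl)cc2)c1`) has not yet been measured. It differs from compound 3 in one place: pyridin-4-yl in place of trifluoromethyl on a saturated chain carbon bound to an oxygen on an aromatic ring. This is pyridin-4-yl in place of trifluoromethyl on a saturated chain carbon bound to an oxygen on an aromatic ring.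

Going by the values given here, two measured steps bear on this change, since both arrive at the 2,2,2-trifluoroethyl group of compound 3: a 9.1-fold lower number from compound 1 to compound 3 (0.96 log units; beyond the scatter) and a 4.3-fold lower number from compound 2 to compound 3 (0.63 log units; beyond the scatter). Both lie beyond the scatter. The remaining step, a 2.1-fold lower number from compound 1 to compound 2 (0.33 log units; beyond the scatter), is smaller. Among the compounds with values here, no measured compound carries pyridin-4-yl, so these steps give only a rough guide. Leaving the trifluoromethyl group is expected to raise the number, by a modest step of similar size in this assay. The expected change is a 3.9-fold higher number from compound 3 to compound 4 (0.59 log units; beyond the scatter). For compound 4 the expected value is 0.09 mL/min/kg, with an estimated range of 0.025 mL/min/kg to 0.3 mL/min/kg.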

Compound 4, clearance: 0.118 mL/min/kg
Compound 4: the middle estimate sits 1.3-fold (0.12 log units) below what was measured, and the stated range covers the measured number.
By their numbers in this assay, from the lowest: compound 3; then compounds 2, 4 and 1 (each within the scatter of the next, the first and the last beyond it).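

In this assay, the change from trifluoromethyl to pyridin-4-yl on this saturated chain carbon gives a 5.1-fold higher number from compound 3 to compound 4 (0.71 log units; beyond the scatter), so a ring here does not keep the low number of the 2,2,2-trifluoroethyl group. Going by these compounds alone, the (pyridin-4-yl)methyl group does not separate from the other two groups on this oxygen, with a 1.2-fold higher number from compound 2 to compound 4 (0.08 log units; within the scatter) and a 1.8-fold lower number from compound 1 to compound 4 (0.25 log units; within the scatter), leaving 2,2,2-trifluoroethyl as the only group here whose steps to all the others lie beyond the scatter. Nothing available accounts for these differences.

As far as these compounds go, it remains open whether a 2,2-difluoroethyl group or a longer fluorinated chain would stay close to compound 3 at 0.023 mL/min/kg. From the compounds shown here alone, it is also open whether benzyl, or pyridin-3-ylmethyl, would give a number like that of compound 4.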